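Methoxy pattern variation on a hydroxyphenyl enone series

The compounds below may be only part of what the source reports. "The series", "measured", "known", "first", "only" and "open" are said of these compounds alone.

Measured in a functional assay (Homo sapiens) for inhibition; a lower number here means a stronger inhibitor, a higher number a weaker inhibitor:
compound 1 `COc1cccc(OC)c1/C=C/C(=O)c1ccc(O)cc1` gives 60000 nM
compound 2 `COc1cc(OC)c(/C=C/C(=O)c2ccc(O)cc2)c(OC)c1` gives 44000 nM
compound 3 `COc1ccc(OC)c(/C=C/C(=O)c2ccc(O)cc2)c1` gives 22000 nM

Compound 1 and compound 2 are linked by a single change, (methoxy in place of hydrogen on an aromatic carbon), and the step it made is a 1.4-fold lower number from compound 1 to compound 2 (0.13 log units; within the scatter). Compound 3 has the same atoms as compound 1 joined differently; the difference between the two cores is not broken down here. Compound 3 returns the lowest number of the three in this assay, though its gap to compound 2 is within the scatter and only its gap to compound 1 lies beyond it.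

Compound 4 `COc1cc(OC)c(OC)cc1/C=C/C(=O)c1ccc(O)cc1` is not yet measured. It comes from compound 3 by methoxy in place of hydrogen on an aromatic carbon. Among the measured compounds shown here, this is the same kind of change as the one taking compound 1 to compound 2, not the same: here the entering group is ortho to a methoxy group and meta to a methoxy group, whereas earlier it was meta to two methoxy groups. Since the earlier step of a 1.4-fold lower number from compound 1 to compound 2 (0.13 log units; within the scatter) stayed within the scatter, the step expected in this assay is a 1.3-fold lower number from compound 3 to compound 4 (0.11 log units; within the scatter), of similar size. Compound 4 is estimated at 17000 nM, with a likely range from 7000 nM to 40000 nM.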

Compound 4, half-maximal inhibitory concentration: 28000 nM
Compound 4: the middle estimate sits 1.6-fold (0.22 log units) below what was measured; the measured number falls inside the stated range.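

In this assay, methoxy in place of hydrogen on an aromatic carbon gives a 1.3-fold higher number from compound 3 to compound 4 (0.10 log units; within the scatter), so on this core the change leaves the number within the scatter. Set beside the earlier step, the two results do not separate, and the direction of neither step can be read: the same change on two cores in this assay, a 1.4-fold lower number (0.13 log units; within the scatter) from compound 1 to compound 2 and a 1.3-fold higher number (0.10 log units; within the scatter) from compound 3 to compound 4, 1.7-fold (0.24 log units) apart, within the scatter of two such steps. This shows that on these two cores the added methoxy group makes no step beyond the scatter; it does not show that the change is without effect on other cores, or that the entering position does not matter, since two steps at different places cannot establish a rule for the series.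

All the variation shown lies in the number and placement of methoxy groups, so it remains open whether ethoxy, a fluorine atom or an amine at the same carbon would give a step beyond the scatter. Also open, going by these compounds, is what replacing the hydroxy group carried by all four compounds, for instance with a carboxylic acid, would do in this assay.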